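Replacing a pyrimidine arm: cytotoxicity expected to stay low

The compounds below may be only part of what the source reports. "The series", "measured", "known", "first", "only" and "open" are said of these compounds alone.

Compound 3 `CCOC(=O)CCCCCOc1cccc(CN(C(=O)c2ccc(-c3cnc(OC)nc3OC)cc2)C(C)C)c1` sits at a limit rather than a number in an ADME assay on Raji cells (Homo sapiens) for cytotoxicity, read by CellTiter-Glo and resazurin assay, with a stated time of 72 h; on this read-out lower numbers stand for an effect already at smaller amounts and higher numbers for an effect only at larger amounts of compound: compound 3 gives > 26000 nM. Compound 1 `CC(C)N(Cc1cccc(OCCCCCC(=O)O)c1)C(=O)c1ccc(-c2ccc3[nH]ccc3c2)cc1` also gives only a limit, > 26000 nM. Compound 2 `CC(C)N(Cc1cccc(OCCCCCC(=O)O)c1)C(=O)c1ccc(-c2ccc3cc[nH]c3c2)cc1` likewise gives a limit, > 26000 nM. Going by the values given here, the one measured step, a step that the two limits leave unreadable from compound 1 to compound 2, cannot be read because the limit of > 26000 nM in this assay, at which 3 of the 3 values shown sit, holds all three values shown. Compound 4 `CCOC(=O)CCCCCOc1cccc(CN(C(=O)c2ccc(-c3cc(F)cc(OC)c3)cc2)C(C)C)c1` differs from compound 3 by 3-fluoro-5-methoxyphenyl in place of 2,4-dimethoxypyrimidin-5-yl on an aromatic carbon. Among the compounds with values here, no measured step bears directly on this change; every measured compound stops at the same limit. Compound 4 is expected to give 40000 nM, with a range from 15000 nM to 100000 nM, most probably again only a limit. The step this estimate means, a step that the limit leaves unreadable from compound 3 to compound 4, is expected to stay within the scatter.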

Compound 4, half-maximal effective concentration: > 26000 nM
Compound 4: no number, only a limit (the forecaster's own chance of this, stated with the estimate: 85%); the middle value is on the limit's open side.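

No step can be read from compound 3 to compound 4, since both stop at a limit rather than a number: the limit of > 26000 nM in this assay, at which 4 of the 4 values shown sit. Going by these compounds, how far compound 1, compound 2, compound 3 and compound 4 truly differ in cytotoxicity stays open.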